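This account rests on a few compounds, and the source may have more. Where it says the series, first, only, none or still open, it means among the compounds named here.

Compounds measured so far in a functional assay on MV4-11 cells (Homo sapiens) for antiproliferative activity, read by luminescence and CellTiter-Glo, with a stated time of 72 h; a higher number here means a weaker inhibitor, a lower number a stronger inhibitor
Compound 1 `COc1ccc(Cn2nc(Nc3ccc(F)cc3)c3ccc(-c4c(C)noc4C)cc32)cc1` gives 9100 nM
Compound 2 `COc1cc2cnn(Cc3ccc(F)cc3)c2cc1-c1c(C)noc1C` gives 1900 nM
Compound 3 `CNc1cc(-c2ccc3cnn(Cc4ccc(C)cc4)c3c2)cn(C)c1=O` gives 3280 nM

Compound 3 holds the second highest of the three numbers. Its gap to compound 2 lies within the scatter, while its gap to compound 1 lies beyond it.

The next step starts from compound 3. Compound 4 `CNc1cc(-c2ccc3cnn(CC4CCCCC4)c3c2)cn(C)c1=O` carries cyclohexyl in place of 4-methylphenyl on a saturated chain carbon bound to an aromatic nitrogen. The same difference can be read as 4-methylbenzyl to cyclohexylmethyl.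

Going by the values given here, no two measured compounds differ in one place, so the data give no direct reading of this change. With nothing to set a direction, the estimate stays close to compound 3, which gives 3280 nM in this assay. The range is kept wide, and more room is left towards weaker inhibition than towards stronger inhibition. The expected step is a 1.1-fold higher number from compound 3 to compound 4 (0.03 log units; within the scatter) and it is expected to stay within the scatter. Compound 4 is estimated at 3500 nM with 1200 nM to 10000 nM as the expected range.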

Compound 4, half-maximal inhibitory concentration: 2690 nM
Estimate against measurement, compound 4: 1.3-fold (0.11 log units) above; the measured number falls inside the stated range.
By their numbers in this assay, from the lowest: compounds 2, 4 and 3 (each within the scatter of the next); then compound 1.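

In this assay, going by these compounds alone, the exchange of 4-methylphenyl for cyclohexyl on a saturated chain carbon bound to an aromatic nitrogen gives a 1.2-fold lower number from compound 3 to compound 4 (0.09 log units; within the scatter), the first reading of a change made in one place. Within the data shown here, at this position, then, the one six-membered aromatic ring of compound 3 and the one six-membered non-aromatic ring of compound 4 cannot be told apart in this assay, so an aromatic ring is not required here for this pair, though the single step sets no trend. No other measurement in hand bears on this step, and its result remains without an explanation.

From the compounds shown here alone, what remains open is whether a ring is needed on this chain carbon at all, which a plain butyl chain or a smaller cyclopropyl ring would test, and whether a group carrying an amine or a carboxylic acid would move the number beyond the scatter. Also open, going by these compounds, is whether the same exchange reads alike on the core of compound 1 or of compound 2.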